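Replacing a urea with a sulfonamide on a shared core

The source may hold more compounds than are shown below. What is called first, only, known or untested is meant among the compounds shown, and "the series" means these compounds.

Compound 3 `CCCCc1ccc(CNC(=O)Nc2ccccc2)c(=O)n1Cc1ccc(-c2ccccc2-c2nn[nH]n2)cc1` gives 30 nM in a functional assay (aorta) for antagonist activity, with Oryctolagus cuniculus as the target (on this read-out lower numbers stand for stronger inhibition and higher numbers for weaker inhibition), the highest of the three numbers measured. Compound 1 `CCCCc1ccc(CN(Cc2ccccc2)S(C)(=O)=O)c(=O)n1Cc1ccc(-c2ccccc2-c2nn[nH]n2)cc1` gives 2 nM and compound 2 `CCCCc1ccc(CN(C)S(=O)(=O)c2ccccc2)c(=O)n1Cc1ccc(-c2ccccc2-c2nn[nH]n2)cc1` gives 2 nM. Compound 4 `CCCCc1ccc(CN(C)S(=O)(=O)c2ccc(C)cc2)c(=O)n1Cc1ccc(-c2ccccc2-c2nn[nH]n2)cc1` is not yet measured; it differs from compound 3 by methyl((4-methylphenyl)sulfonyl)amino in place of (phenylcarbamoyl)amino on a saturated chain carbon bound to an aromatic carbon. Going by the values given here, two measured steps bear on this change: a 15-fold higher number from compound 1 to compound 3 (1.18 log units; beyond the scatter) and a 15-fold higher number from compound 2 to compound 3 (1.18 log units; beyond the scatter). Both end at the (phenylcarbamoyl)amino group of compound 3 and carry a large increase; compound 4 leaves that group for one close to the methyl(phenylsulfonyl)amino of compound 2. Compound 4 is therefore expected to give a clearly lower number, a 12-fold lower number from compound 3 to compound 4 (1.08 log units; beyond the scatter). For compound 4 the estimate is 2.5 nM, with a range from 1 nM to 7 nM.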

Compound 4, half-maximal inhibitory concentration: 8 nM
Compound 4: the middle estimate sits 3.2-fold (0.51 log units) below what was measured; the whole stated range lies below it.
By their numbers in this assay, from the lowest: compounds 1 and 2 (each within the scatter of the next); then compound 4; then compound 3.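

In this assay, methyl in place of hydrogen on an aromatic carbon gives a 4.0-fold higher number from compound 2 to compound 4 (0.60 log units; beyond the scatter), so the sulfonamide series responds to a single added methyl, which the match between compound 1 and compound 2 did not reveal. The exchange with benzyl(methylsulfonyl)amino now also registers, with a 4.0-fold higher number from compound 1 to compound 4 (0.60 log units; beyond the scatter). Leaving (phenylcarbamoyl)amino still lowers the number, but the methylated group gives only a 3.8-fold lower number from compound 3 to compound 4 (0.57 log units; beyond the scatter).

Nothing available explains the effect of the added methyl. As far as these compounds go, it remains open whether a chlorine or a methoxy group in place of that methyl would raise the number in the same way.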